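Replacing a Dimethoxyanilino Partner with a Fluoroanilino One

The source may report more compounds than this note shows. Statements on the series, on what has been measured and on what is new or still open speak of the compounds shown alone.

Compound 2 `COc1ccc(N/C=C\C(=O)c2nc(-c3ccc(C(F)(F)F)cc3)n3ccccc23)cc1OC` shares its core with compound 1 `COc1ccc(-c2nc(C(=O)/C=C\Nc3ccc4[nH]ccc4c3)c3ccccn23)cc1` and compound 3 `COc1ccc(N/C=C\C(=O)c2nc(-c3ccc(OC)cc3)n3ccccc23)cc1`. In a functional assay on B16-F10 cells (Mus musculus) for cytotoxicity, read by MTT assay, with a stated time of 48 h (a higher number here means a weaker inhibitor, a lower number a stronger inhibitor), compound 1 gives 5120 nM. In this assay compound 3 gives 2120 nM. Within the data shown here, the step of a 2.4-fold lower number from compound 1 to compound 3 (0.38 log units; beyond the scatter) is the only measured change on the amine nitrogen. For compound 2, this assay reports no number but a limit, > 30000 nM; this is the limit of > 30000 nM in this assay, at which 1 of the 3 values shown sits. Compound 4 `O=C(/C=C\Nc1ccc(F)cc1)c1nc(-c2ccc(C(F)(F)F)cc2)n2ccccc12` differs from compound 2 by 4-fluorophenyl in place of 3,4-dimethoxyphenyl on an amine nitrogen. Among the measured compounds shown here, no measured step exchanges a 3,4-dimethoxyphenyl for a 4-fluorophenyl; the step from compound 1 to compound 3, which swaps one aryl group for another on the same nitrogen, was modest in size. Compound 2 stands at a limit, and the size of the step to compound 4 in this assay therefore cannot be read from a measured number; only a modest move, in either direction, is expected. In this assay compound 4 is expected to give about 25000 nM, between 8000 nM and 60000 nM, an estimated step of an at least 1.2-fold lower number from compound 2 to compound 4 (0.07 log units; that floor lies within the scatter).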

Compound 4, half-maximal inhibitory concentration: > 30000 nM
Compound 4 was reported as a limit; the forecaster's own chance of this, stated with the estimate: 45%; middle value at least 1.2-fold (0.07 log units) away from the limit.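

Among these compounds, compound 4, like compound 2, is reported in this assay only as a limit, so no step between compound 2 and compound 4 can be read: the limit of > 30000 nM in this assay, at which 2 of the 4 values shown sit. The compounds shown leave open whether 4-fluorophenyl in place of 3,4-dimethoxyphenyl on an amine nitrogen changes the value at all.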